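The source may hold more compounds than are shown below. What is called first, only, known or untested is meant among the compounds shown, and "the series" means these compounds.

Working notes on the series. Among the compounds with values here, in a functional assay on the whole organism (Platelet) for inhibition, with Rattus norvegicus as the target, at a dose of 2 mg/kg (on this read-out higher numbers stand for a stronger effect at the one dose given and lower numbers for a weaker effect), compound 2 `CC/C=C/C(=O)Oc1cc2c(s1)CCN([C@H](C(=O)OC)c1ccccc1Cl)C2` stands lowest of the two numbers so far, at 62.9%, while compound 1 `C/C=C/C(=O)Oc1cc2c(s1)CCN([C@H](C(=O)OC)c1ccccc1Cl)C2` gives 77%. Within the data shown here, the only step in hand is a number 14.1 percentage points lower from compound 1 to compound 2 (beyond the scatter), which is a modest loss beyond the scatter.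

Compound 3 `CCC/C=C/C(=O)Oc1cc2c(s1)CCN([C@H](C(=O)OC)c1ccccc1Cl)C2` differs from compound 2 by methyl in place of hydrogen on a saturated chain carbon, two bonds along the chain from a double-bonded chain carbon, the same difference read one bond further out as ethyl to propyl. Among the measured compounds shown here, the step from compound 1 to compound 2 is the nearest precedent: it is also methyl in place of hydrogen on the same chain, one bond closer to the double-bonded chain carbon, and it lowered the read-out modestly. On that single precedent a further modest drop, or no change beyond the scatter, is expected, with a number 10.9 percentage points lower from compound 2 to compound 3 (beyond the scatter) as the working step. Compound 3 is therefore estimated at 52%, in the range 36% to 68%.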

Compound 3, a percentage reported as inhibition, in the whole organism at one dose (the size of the read-out at that dose, not a potency): 74.3%
Estimate against measurement, compound 3: 22.3 percentage points below, and the stated range ends below it.
By their numbers in this assay, from the lowest: compound 2; then compounds 3 and 1 (each within the scatter of the next).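

Methyl in place of hydrogen on a saturated chain carbon does not have one fixed outcome along this chain: two bonds along the chain from a double-bonded chain carbon, this assay shows a number 11.4 percentage points higher from compound 2 to compound 3 (beyond the scatter) and thus the opposite direction to a number 14.1 percentage points lower from compound 1 to compound 2 (beyond the scatter). Taken together, the two changes give a number 2.7 percentage points lower from compound 1 to compound 3 (within the scatter), so across these three compounds the read-out does not follow chain length in one direction, and compound 2 goes against any steady trend. No measurement in hand bears on the reason for this reversal.

As far as these compounds go, whether a longer chain, such as hexenyl, would hold the read-out of compound 3 stays open. So does the outcome for a chain ending in an amine or a carboxylic acid.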